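From a ring to isopropyl on the oxygen

This account rests on a few compounds, and the source may have more. Where it says the series, first, only, none or still open, it means among the compounds named here.

- compound 1 `COc1cc(N2CCC(C)(O)CC2)ccc1Nc1nc(O[C@H]2CCOC(C)(C)C2)c2cc[nH]c2n1` gives 71 nM
- compound 2 `COc1cc(C(=O)N(C)C)ccc1Nc1nc(O[C@H]2CCOC(C)(C)C2)c2cc[nH]c2n1` gives 131 nM

In a functional assay on CAL-51 cells (Homo sapiens) for antiproliferative activity, read by luminescence and CellTiter-Glo, with a stated time of 3 days (a higher number here means a weaker inhibitor, a lower number a stronger inhibitor), compound 2 gives 131 nM and compound 1 gives 71 nM, so the two cannot be told apart. The next compound, compound 3 `COc1cc(C(=O)N(C)C)ccc1Nc1nc(OC(C)C)c2cc[nH]c2n1`, keeps everything in compound 2 except one group: isopropyl in place of 2,2-dimethyloxan-4-yl on an oxygen on an aromatic ring. Among the measured compounds shown here, the only measured step, a 1.8-fold higher number from compound 1 to compound 2 (0.27 log units; within the scatter), lies within the scatter and changes a different place on the core. For the measured compounds named here, it therefore offers no direct guide, and no measured step covers a change at this oxygen. Since a large ring-bearing group gives way to a small chain, a moderate rise in the number in this assay is expected, though with wide uncertainty. The expected change is a 2.0-fold higher number from compound 2 to compound 3 (0.30 log units; within the scatter). For compound 3 the estimated value is 260 nM, with an expected range of 70 nM to 1000 nM.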

Compound 3, half-maximal inhibitory concentration: 1270 nM
Estimate against measurement, compound 3: 4.9-fold (0.69 log units) below; the measured number lies above the stated range.
By their numbers in this assay, from the lowest: compounds 1 and 2 (each within the scatter of the next); then compound 3.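

In this assay the oxygen substituent proves to matter: putting isopropyl in place of 2,2-dimethyloxan-4-yl gives a 9.7-fold higher number from compound 2 to compound 3 (0.99 log units; beyond the scatter). The earlier change on the aromatic carbon stayed within the scatter, so this is the first change shown that clearly separates two compounds, with the ring-bearing group on the side of the lower number, meaning the stronger inhibitor. Nothing available explains why the number rises.

This single pair changes the ring, its oxygen, its two methyl groups and the heavy-atom count all at once, and it leaves open which of these carries the difference. Also open, as far as these compounds go, is how a cyclohexyl group, with a ring but no ring oxygen, or a longer chain such as butyl would behave on the same oxygen.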